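Trifluoromethyl for Methyl on the Benzyl Arm

The source may hold more compounds than are shown below. What is called first, only, known or untested is meant among the compounds shown, and "the series" means these compounds.

Within the data shown here, compound 2 `Cc1ccc(CSc2cc(Cl)c(C)cc2S(=O)(=O)/N=C(\N)n2nccc2-c2ccccc2)cc1` gives 0.13 h in an ADME assay on microsomes from liver (Homo sapiens) for metabolic stability, read by LC-MS, using NADPH, tested at 5 uM (on this read-out higher numbers stand for a longer-lived compound and lower numbers for a shorter-lived compound), and the only other measured compound, compound 1 `Cc1cc(S(=O)(=O)/N=C(\N)n2nccc2-c2ccccc2)c(SCc2ccccc2)cc1Cl`, gives 0.0772 h, which lies within the scatter of it. Among the measured compounds shown here, the one measured step, a 1.7-fold higher number from compound 1 to compound 2 (0.23 log units; within the scatter), came from methyl in place of hydrogen on an aromatic carbon. Compound 3 `Cc1cc(S(=O)(=O)/N=C(\N)n2nccc2-c2ccccc2)c(SCc2ccccc2C(F)(F)F)cc1Cl` is not yet measured; it differs from compound 2 by 2-(trifluoromethyl)phenyl in place of 4-methylphenyl on a saturated chain carbon bound to a sulfur. That change sits on a different part of the molecule than the measured step, so no direction can be read from it. Compound 3 is therefore expected near 0.13 h, between 0.05 h and 0.35 h. This estimate means no change at the digits printed from compound 2 to compound 3 (within the scatter), nothing beyond the scatter.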

Compound 3, half-life: 0.15 h
The estimate for compound 3 lay 1.2-fold (0.06 log units) below the measured number; the measured number falls inside the stated range.
By their numbers in this assay, from the lowest: compounds 1, 2 and 3 (each within the scatter of the next).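

In this assay, 2-(trifluoromethyl)phenyl in place of 4-methylphenyl on the saturated chain carbon bound to a sulfur gives a 1.2-fold higher number from compound 2 to compound 3 (0.06 log units; within the scatter), and trifluoromethyl in place of hydrogen on an aromatic carbon gives a 1.9-fold higher number from compound 1 to compound 3 (0.29 log units; within the scatter). Neither step lies beyond the scatter, so across these three compounds, a trifluoromethyl on the benzyl arm shows no clear shift in half-life, just as the methyl did. Nothing available explains this result. Going by these compounds, whether an amine or a carboxylic acid on this ring, or a longer chain in place of the benzyl arm, would move the half-life beyond the scatter remains open.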